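This account rests on a few compounds, and the source may have more. Where it says the series, first, only, none or still open, it means among the compounds named here.

Measured so far:
compound 1 `CCn1c(C(=O)N[C@H](C)C(=O)OC)ccc1C(CC)(CC)c1ccc(OCS(=O)(=O)c2ccccc2)c(C)c1` — > 50000 nM
compound 2 `CCn1c(C(=O)NCCN)ccc1C(CC)(CC)c1ccc(OCS(=O)(=O)c2ccccc2)c(C)c1` — 6890 nM

In a functional assay on PC-3 cells (Homo sapiens) for antiproliferative activity, read by MTT assay, with a stated time of 24 h (on this read-out higher numbers stand for weaker inhibition and lower numbers for stronger inhibition), compound 1 gives only a limit, > 50000 nM, as the line the limit of > 50000 nM in this assay, at which 1 of the 2 values shown sits, records. Among the measured compounds shown here, compound 2 `CCn1c(C(=O)NCCN)ccc1C(CC)(CC)c1ccc(OCS(=O)(=O)c2ccccc2)c(C)c1` is the one compound with an actual number, 6890 nM. For the measured compounds named here, the one step known, an at least 7.2-fold lower number from compound 1 to compound 2 (0.86 log units; beyond the scatter), shows that what sits on the amide-type nitrogen moves the read-out strongly. Compound 3 `CCn1c(C(=O)NC2(CO)CC2)ccc1C(CC)(CC)c1ccc(OCS(=O)(=O)c2ccccc2)c(C)c1` differs from compound 2 by 1-(hydroxymethyl)cyclopropyl in place of 2-aminoethyl on an amide-type nitrogen. Since the step of an at least 7.2-fold lower number from compound 1 to compound 2 (0.86 log units; beyond the scatter) shows the 2-aminoethyl group mattering, its loss in compound 3 is expected to cost, with the step of a 2.2-fold higher number from compound 2 to compound 3 (0.34 log units; beyond the scatter) anticipated. Compound 3 is estimated at 15000 nM, within 5000 nM to 50000 nM.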

Compound 3, half-maximal inhibitory concentration: 3560 nM
The estimate for compound 3 lay 4.2-fold (0.62 log units) above the measured number; the whole stated range lies above it.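

The step of a 1.9-fold lower number from compound 2 to compound 3 (0.29 log units; within the scatter) shows that the amine of the 2-aminoethyl group is not required on the amide-type nitrogen, since 1-(hydroxymethyl)cyclopropyl cannot be told apart from it. Compound 3 also stands clear of compound 1, with an at least 14-fold lower number from compound 1 to compound 3 (1.14 log units; beyond the scatter), so two different groups now do so at this nitrogen. That step starts from a limit of compound 1 and not from a number: the limit of > 50000 nM in this assay, at which 1 of the 3 values shown sits.

Going by these compounds, it remains open whether a carboxylic acid or a longer chain ending in a hydroxyl would hold this level. On these data alone, what sets 1-(methoxycarbonyl)ethyl apart from the other two groups also remains open.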